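From a Hexyloxy Chain to a Methylcyclohexyl Ring

The source may hold more compounds than are shown below. What is called first, only, known or untested is meant among the compounds shown, and "the series" means these compounds.

compound 1 `O=C(NCc1ccc(C(F)(F)F)nc1N1CCCCC1)Nc1cccc2[nH]c(=O)ccc12`: 0.75 nM
compound 2 `CCCCCCOc1nc(C(F)(F)F)ccc1CNC(=O)Nc1cccc2[nH]c(=O)ccc12`: 3.19 nM

In an assay on HEK cells for antagonist activity at transient receptor potential cation channel subfamily V member 1 (Homo sapiens), read by FLIPR (a lower number here means a stronger inhibitor, a higher number a weaker inhibitor), compound 1 gives 0.75 nM and compound 2 gives 3.19 nM. Among the compounds with values here, compound 2 stands with the higher number of the two, and the only measured step, a 4.3-fold higher number from compound 1 to compound 2 (0.63 log units; beyond the scatter), bears on what comes next. Compound 3 `CC1CCC(c2nc(C(F)(F)F)ccc2CNC(=O)Nc2cccc3[nH]c(=O)ccc23)CC1` differs from compound 2 by 4-methylcyclohexyl in place of hexyloxy on an aromatic carbon. Within the data shown here, this change brings back a six-membered ring, as compound 1 carries one, so a step back toward the number of compound 1 is expected, though a smaller one: no measured compound carries a ring of carbon only. The number for compound 3 is estimated at 1.5 nM, within 0.5 nM to 5 nM, an expected step of a 2.1-fold lower number from compound 2 to compound 3 (0.33 log units; beyond the scatter).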

Compound 3, half-maximal inhibitory concentration: 1.44 nM
Estimate against measurement, compound 3: 1.0-fold (0.02 log units) above; the measured number falls inside the stated range.
By their numbers in this assay, from the lowest: compounds 1 and 3 (each within the scatter of the next); then compound 2.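

In this assay, replacing the hexyloxy chain with 4-methylcyclohexyl, a ring with the same count of heavy atoms but no oxygen, gives a 2.2-fold lower number from compound 2 to compound 3 (0.35 log units; beyond the scatter) at this aromatic carbon next to the ring nitrogen. The position also accepts a ring joined through carbon as well as one joined through nitrogen, since the change from piperidin-1-yl gives a 1.9-fold higher number from compound 1 to compound 3 (0.28 log units; within the scatter) and stays close. No measurement shown here explains either step.

From the compounds shown here alone, what the methyl group itself contributes stays open, as does the outcome with plain cyclohexyl or with morpholin-4-yl at this place.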